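Dimethylamino added to the benzyl ring of compound 1

This account rests on a few compounds, and the source may have more. Where it says the series, first, only, none or still open, it means among the compounds named here.

Compound 1 `CCN(CCCOc1ccc(C(=O)/C=C/c2ccc(N(C)C)cc2)c(O)c1)Cc1ccccc1` and compound 2 `COc1ccc(C(=O)/C=C/c2ccc(N(C)C)cc2)c(O)c1` share the same core and have been measured in an assay on isolated protein for inhibition of Amine oxidase [flavin-containing] A (Homo sapiens); on this read-out higher numbers stand for weaker inhibition and lower numbers for stronger inhibition. In this assay compound 1 gives 82600 nM, the highest of the two numbers. For the measured compounds named here, compound 2 gives 7620 nM, a lower number; the two structures differ in more than one place, so the gap between them is not tied to a single change, and no step within the pair can be read off. Compound 3 `CCN(CCCOc1ccc(C(=O)/C=C/c2ccc(N(C)C)cc2)c(O)c1)Cc1ccccc1N(C)C` has not yet been measured in this assay. It differs from compound 1 in one place: dimethylamino in place of hydrogen on an aromatic carbon. Going by the values given here, the change sits on the benzyl ring of the tertiary amine side chain, far from the part of the core in which compound 1 and compound 2 differ, and nothing among the measured compounds shows what such a substitution does. The step from compound 1 to compound 3 is therefore expected to be small, a 1.3-fold lower number from compound 1 to compound 3 (0.10 log units; within the scatter), with no direction beyond the scatter asserted. In this assay compound 3 is estimated at 65000 nM, within a range from 20000 nM to 200000 nM.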

Compound 3, half-maximal inhibitory concentration: 23600 nM
Compound 3: middle estimate off by 2.8-fold (0.44 log units), on the high side; low and high end bracket the measured number.
By their numbers in this assay, from the lowest: compound 2; then compound 3; then compound 1.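

The benzyl ring of the tertiary amine side chain is not a silent place in this assay: dimethylamino in place of hydrogen on an aromatic carbon, ortho to a large group, gives a 3.5-fold lower number from compound 1 to compound 3 (0.54 log units; beyond the scatter). For the compounds shown here, this is the first single change with a readable step, since the earlier pair differs in more than one place and could show nothing about this ring on its own. Nothing measured here accounts for the step.

Whether the step belongs to dimethylamino as such or to this particular place on the ring stays open, as the compounds shown carry the group at this one place only, and neither a primary amine nor a methoxy group on the same aromatic carbon stands among them. Also open, as far as these compounds go, is whether the same change would give a similar step with a longer chain linking the tertiary amine to the shared core.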